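The source may hold more compounds than are shown below. What is called first, only, known or untested is meant among the compounds shown, and "the series" means these compounds.

In a functional assay on SK-OV-3 cells (Homo sapiens) for cytotoxicity (on this read-out higher numbers stand for weaker inhibition of growth and lower numbers for stronger inhibition of growth), compound 1 `COc1ccc(C2=C(c3ccc(SC)cc3)CC3CCCN3C2=O)cc1` gives 3000 nM, compound 2 `CSc1ccc(C2=C(c3ccc(OCC4CO4)cc3)C(=O)N3CCCC3C2)cc1` gives 10000 nM and compound 3 `CSc1ccc(C2=C(c3ccc(C)cc3)C(=O)N3CCCC3C2)cc1` gives 9000 nM. Compound 3 thus sits at the upper end of these numbers: the gap to its nearest neighbour is a 1.1-fold lower number from compound 2 to compound 3 (0.05 log units; within the scatter), and the gap to its furthest is a 3.0-fold higher number from compound 1 to compound 3 (0.48 log units; beyond the scatter). Compound 4 `CSc1ccc(C2=C(c3ccc(F)cc3)C(=O)N3CCCC3C2)cc1` is the next analogue, and its difference from compound 3 is fluoro in place of methyl on an aromatic carbon, which turns 4-methylphenyl into 4-fluorophenyl. Two measured steps involve this same place, and both end in the methyl group: a 3.0-fold higher number from compound 1 to compound 3 (0.48 log units; beyond the scatter) and a 1.1-fold lower number from compound 2 to compound 3 (0.05 log units; within the scatter). Exchange at this position has therefore ranged from nothing beyond the scatter to a modest shift, even with a group as large as the (oxiran-2-yl)methoxy of compound 2. Going by the values given here, no fluoro analogue has been measured, so the direction remains uncertain. The expected outcome is a 1.3-fold lower number from compound 3 to compound 4 (0.11 log units; within the scatter), which would be a small step at most. For compound 4, the estimated value in this assay is 7000 nM, with an expected range of 3000 nM to 14000 nM.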

Compound 4, concentration for 50% growth inhibition: 30000 nM
Compound 4: middle estimate off by 4.3-fold (0.63 log units), on the low side, and the stated range ends below it.
By their numbers in this assay, from the lowest: compound 1; then compounds 3 and 2 (each within the scatter of the next); then compound 4.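

The fluoro group proves to be the least favourable of the four groups at this position in this assay, with a 3.3-fold higher number from compound 3 to compound 4 (0.52 log units; beyond the scatter) and a 3.0-fold higher number from compound 2 to compound 4 (0.48 log units; beyond the scatter). The position therefore responds to the exchange of a single heavy atom, whereas the much larger (oxiran-2-yl)methoxy of compound 2 stays within the scatter of the methyl of compound 3, so the heavy-atom count of the group does not order these numbers. The span at this position also widens to a 10-fold higher number from compound 1 to compound 4 (1.00 log units; beyond the scatter), with the methoxy of compound 1 still giving the lowest number.

Nothing available explains why fluoro and methoxy lie so far apart. From the compounds shown here alone, whether a hydroxy group, an amine or a carboxylic acid on this aromatic carbon would give a number lower than that of compound 1 remains open.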